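A few compounds are considered here, and "the series" means these few. Any claim that something is new, unique, unknown or untested is made for them only; others in the source may bear on it.

Measured in a functional assay on MV4-11 cells (Homo sapiens) for antiproliferative activity, read by luminescence and CellTiter-Glo, with a stated time of 72 h; a lower number here means a stronger inhibitor, a higher number a weaker inhibitor:
- compound 1 `CNc1cc(-c2ccc3cnn(Cc4ccc(F)cc4)c3c2)cn(C)c1=O`: 2390 nM
- compound 2 `CNc1cc(-c2ccc3cnn(Cc4ccc(C)cc4)c3c2)cn(C)c1=O`: 3280 nM
- compound 3 `CNc1cc(-c2ccc3cnn(Cc4ccc(C(F)(F)F)cc4)c3c2)cn(C)c1=O`: 4370 nM

Compound 3 gives 4370 nM, which cannot be told apart from the other two values. The steps are a 1.8-fold higher number from compound 1 to compound 3 (0.26 log units; within the scatter) and a 1.3-fold higher number from compound 2 to compound 3 (0.12 log units; within the scatter).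

In compound 4 `CNc1cc(-c2ccc3cnn(Cc4ccc(OC)c(F)c4)c3c2)cn(C)c1=O`, 3-fluoro-4-methoxyphenyl comes in place of 4-(trifluoromethyl)phenyl on a saturated chain carbon bound to an aromatic nitrogen (3-fluoro-4-methoxyphenyl in place of 4-(trifluoromethyl)phenyl on a saturated chain carbon bound to an aromatic nitrogen).

The closest evidence is the swaps of one group on an aromatic carbon, including a 1.4-fold higher number from compound 1 to compound 2 (0.14 log units; within the scatter). Among the compounds with values here, all of them stayed small, but no measured compound carries a methoxy group, so this guide is imperfect. In this assay, no shift beyond the scatter is expected, and the expected step is a 1.6-fold lower number from compound 3 to compound 4 (0.19 log units; within the scatter). For compound 4 the estimate is 2800 nM, with an expected range from 1100 nM to 7000 nM.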

Compound 4, half-maximal inhibitory concentration: 4980 nM
For compound 4 the middle estimate is 1.8-fold (0.25 log units) below the measured one; measured number inside the range.
By their numbers in this assay, from the lowest: compounds 1, 2, 3 and 4 (each within the scatter of the next, the first and the last beyond it).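

In this assay, within the data shown here, placing 3-fluoro-4-methoxyphenyl on this saturated chain carbon bound to an aromatic nitrogen gives a 1.1-fold higher number from compound 3 to compound 4 (0.06 log units; within the scatter) and a 1.5-fold higher number from compound 2 to compound 4 (0.18 log units; within the scatter) but also a 2.1-fold higher number from compound 1 to compound 4 (0.32 log units; beyond the scatter) which is the first step beyond the scatter, though only a modest one. A ring with two groups, one containing oxygen, therefore stays level with compound 2 and compound 3 but does not match compound 1. No measured evidence here explains these differences.

Still open, from the compounds shown here alone, is whether an amine or a carboxylic acid on this ring would move the number further. A longer chain in place of this saturated chain carbon also remains untested among the compounds shown.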